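This account rests on a few compounds, and the source may have more. Where it says the series, first, only, none or still open, it means among the compounds named here.

Measured so far in an assay on isolated protein for inhibition of DNA nucleotidylexotransferase (Homo sapiens), read by scintillation counting, with a stated time of 10 min; a lower number here means a stronger inhibitor, a higher number a weaker inhibitor:

Compound 1, `C/C=C/n1cc(/C=C/C(=O)CC(=O)C(=O)OCC)c2ccccc21`, gives only a limit, > 40 uM.
Compound 2, `CCOC(=O)C(=O)CC(=O)/C=C/c1cn(-c2ccc(Cl)cc2)c2ccccc12`, also gives only a limit, > 40 uM.
Compound 3, `O=C(/C=C/c1cn(-c2ccc(Cl)cc2)c2ccccc12)CC(=O)C(=O)O`, gives 31 uM.

Among the measured compounds shown here, compound 3 thus stands as the only compound of the three with a number in this assay; the other two sit at the limit of > 40 uM in this assay, at which 2 of the 3 values shown sit.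

Compound 4, `COc1ccc(Cn2cc(/C=C/C(=O)CC(=O)C(=O)O)c3ccccc32)cc1`, differs from compound 3 in one place: 4-methoxybenzyl in place of 4-chlorophenyl on an aromatic nitrogen. The measured steps bear on it only loosely. The step from compound 1 to compound 2 also changes the group on the aromatic nitrogen, but a step that the two limits leave unreadable from compound 1 to compound 2, so its size cannot be read. The step from compound 2 to compound 3 lies elsewhere, at the oxygen next to a carbonyl group, and gave an at least 1.2-fold lower number from compound 2 to compound 3 (0.11 log units; that floor lies within the scatter). With no readable step at the aromatic nitrogen, no shift beyond the scatter is expected from compound 3 to compound 4, and the estimated step is a 1.0-fold lower number from compound 3 to compound 4 (0.01 log units; within the scatter). For compound 4 the expected value in this assay is 30 uM, estimated to fall between 10 uM and 100 uM.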

Compound 4, concentration for 50% inhibition: 10 uM
For compound 4 the middle estimate is 3.0-fold (0.48 log units) above the measured one, within the range that was stated.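

The group on the aromatic nitrogen now gives a readable step in this assay: 4-methoxybenzyl in place of 4-chlorophenyl gives a 3.1-fold lower number from compound 3 to compound 4 (0.49 log units; beyond the scatter). Compound 1 and compound 2 each give only a limit, so the earlier step at this nitrogen cannot be read: the limit of > 40 uM in this assay, at which 2 of the 4 values shown sit. The position thus responds to the group it carries, though this rests on one modest step between two compounds that both hold the carboxylic acid.

The change swaps the aryl group for a benzyl and brings in the methoxy group in the same step, so the compounds shown do not tell which of the two goes with the lower number. On these data alone, how plain benzyl, 4-chlorobenzyl or a longer chain such as 2-phenylethyl would read on this nitrogen stays open.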